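Inverting one stereocentre of compound 2

The compounds below may be only part of what the source reports. "The series", "measured", "known", "first", "only" and "open" are said of these compounds alone.

Within the data shown here, in a functional assay on HL-60 cells (Homo sapiens) for antiproliferative activity, read by MTT assay (a higher number here means a weaker inhibitor, a lower number a stronger inhibitor), compound 2 (`C=C[C@@H]1O[C@H](COCc2ccccc2)[C@@H](OCc2ccccc2)[C@H](OCc2ccccc2)[C@H]1O`) gives 11800 nM and compound 3 (`C=CC[C@@H]1O[C@H](COCc2ccccc2)[C@@H](OCc2ccccc2)[C@H](OCc2ccccc2)[C@H]1O`) gives 15100 nM as the only two numbers. The two stand level, with a 1.3-fold higher number from compound 2 to compound 3 (0.11 log units; within the scatter) for allyl in place of vinyl on a saturated ring carbon. Compound 1 (`CC[C@H]1O[C@H](COCc2ccccc2)[C@@H](OCc2ccccc2)[C@H](OCc2ccccc2)[C@H]1O`) is recorded as "not active" (no number reported) and yields no number.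

Compound 4 (`C=C[C@H]1O[C@H](COCc2ccccc2)[C@@H](OCc2ccccc2)[C@H](OCc2ccccc2)[C@H]1O`) differs from compound 2 only in configuration as drawn (the two compounds have the same atoms and bonds and differ only in configuration as drawn: 1 of 5 stereo elements differ; a stereocentre at a saturated ring carbon is drawn S in compound 2 and R in compound 4) and a stereocentre at a saturated ring carbon is drawn S in compound 2 and R in compound 4. Among the measured compounds shown here, no measured step tests a change of configuration. For the measured compounds named here, the one step available concerns the allyl and vinyl groups, so it bears only loosely and sets no size. Compound 1 shows that a number is not assured in this series, which leaves the range wide and leaves some chance of no number at all. The expected size is a 1.2-fold higher number from compound 2 to compound 4 (0.07 log units; within the scatter) and this estimate stays inside the scatter, with no firm direction. For compound 4 the expected value is 14000 nM with an estimated range from 5000 nM to 40000 nM in this assay here.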

Compound 4, half-maximal inhibitory concentration: "not active" (no number reported)
Compound 4: no number reported, and the estimate cannot be compared.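

In this assay compound 4 gives "not active" (no number reported) and compound 2 gives 11800 nM, and no new step can be read between the two. The compounds shown leave open what size of change, if any, goes with the configuration at that saturated ring carbon.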